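The compounds below may be only part of what the source reports. "The series", "measured", "known", "first", "only" and "open" are said of these compounds alone.

Measured compounds:
- compound 1 `CC[C@H]1[C@@H](N)CN1c1cc2c(cc1F)c(=O)c(C(=O)O)cn2C1CC1`: 42.2 ug/mL
- compound 2 `CC[C@H]1[C@@H](N)CN1c1c(F)cc2c(=O)c(C(=O)O)cn(C3CC3)c2c1F`: 55.9 ug/mL
- compound 3 `CNC1(C)CN(c2c(F)cc3c(=O)c(C(=O)O)cn(C4CC4)c3c2F)C1`: 0.5 ug/mL

In a physicochemical assay for solubility, at pH 7.4 (on this read-out higher numbers stand for higher solubility and lower numbers for lower solubility), compound 1 gives 42.2 ug/mL and stands second highest of the three numbers. Its nearest neighbour is compound 2, which in this assay gives 55.9 ug/mL, and the step of a 1.3-fold higher number from compound 1 to compound 2 (0.12 log units; within the scatter) lies within the scatter. Its furthest neighbour is compound 3, which in this assay gives 0.5 ug/mL; the step of a 110-fold lower number from compound 2 to compound 3 (2.05 log units; beyond the scatter) is large and beyond the scatter.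

The unmeasured compound 4 `C[C@H]1[C@H](N)CN1c1cc2c(cc1F)c(=O)c(C(=O)O)cn2C1CC1` differs from compound 1 in one place: a group of 6 heavy atoms (4 carbon, 2 nitrogen; one four-membered non-aromatic ring with 1 hetero atom) in place of a group of 7 heavy atoms (5 carbon, 2 nitrogen; one four-membered non-aromatic ring with 1 hetero atom), on an aromatic carbon. Of the two measured steps, only the swap of one four-membered ring group for another from compound 2 to compound 3 concerns the same place, but that swap exchanges two groups of equal size, whereas the change to compound 4 shortens the group by one carbon and keeps the donor and acceptor count. The fluoro step from compound 1 to compound 2 does not concern this place. For the measured compounds named here, no measured step therefore matches the change closely, and a step within the scatter is expected in this assay, if anything slightly upward.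

For compound 4 the expected value in this assay is 50 ug/mL, within 25 ug/mL to 100 ug/mL, which means the estimated step of a 1.2-fold higher number from compound 1 to compound 4 (0.07 log units; within the scatter).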

Compound 4, solubility: 9.9 ug/mL
The estimate for compound 4 lay 5.1-fold (0.70 log units) above the measured number, and the stated range ends above it.
By their numbers in this assay, from the lowest: compound 3; then compound 4; then compounds 1 and 2 (each within the scatter of the next).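

In this assay, putting the group of 6 heavy atoms in place of the group of 7 heavy atoms, on the aromatic carbon ortho to a fluoro group, gives a 4.3-fold lower number from compound 1 to compound 4 (0.63 log units; beyond the scatter). This place therefore responds to a change in the group even when the four-membered ring, the donor and acceptor counts, the net charge and the number of defined stereocentres all stay the same. The only earlier step at this place, a 110-fold lower number from compound 2 to compound 3 (2.05 log units; beyond the scatter), exchanged groups of equal heavy-atom count, so it could not show that a smaller group here can go with a step beyond the scatter, and no measurement shown explains the drop seen with compound 4.

The compounds shown leave open whether a propyl chain on the four-membered ring would give a higher or lower number than the groups in compound 1 and compound 4. They also leave open whether the same exchange of groups on the core of compound 2, with its added fluoro group, would give a step of similar size.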